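Carbonyl substituent change, compound 2 to compound 3

The source may hold more compounds than are shown below. What is called first, only, known or untested is meant among the compounds shown, and "the series" means these compounds.

Measured in a functional assay on A549 cells (Homo sapiens) for antiproliferative activity, read by MTT assay, with a stated time of 72 h (a lower number here means a stronger inhibitor, a higher number a weaker inhibitor), so far:
- compound 1 `COc1cc(-n2cccc2C(=O)N2CCCCC2)ccc1Nc1ncc(Cl)c(Nc2ccccc2NS(C)(=O)=O)n1` gives > 10000 nM as a limit
- compound 2 `COc1cc(-n2cccc2C(=O)N2CCC(C)CC2)ccc1Nc1ncc(Cl)c(Nc2ccccc2NS(C)(=O)=O)n1` gives 2200 nM as a number

Going by the values given here, compound 2 gives 2200 nM in this assay and holds the only actual number so far. The other value, for compound 1, is only a limit.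

In compound 3 `COc1cc(-n2cccc2C(=O)N2CC(O)C2)ccc1Nc1ncc(Cl)c(Nc2ccccc2NS(C)(=O)=O)n1` the change 3-hydroxyazetidin-1-yl in place of 4-methylpiperidin-1-yl on a carbonyl carbon puts 3-hydroxyazetidin-1-yl in place of 4-methylpiperidin-1-yl on a carbonyl carbon. Among the compounds with values here, one measured step bears on this, and only in part: an at least 4.5-fold lower number from compound 1 to compound 2 (0.65 log units; beyond the scatter) came with methyl in place of hydrogen on a saturated ring carbon. That methyl is absent from compound 3, and the ring changes as well. Within the data shown here, no measured compound carries the 3-hydroxyazetidin-1-yl group, so the single step offers a direction more than a size. A higher number is therefore expected, with a 2.7-fold higher number from compound 2 to compound 3 (0.44 log units; beyond the scatter) as the expected step in this assay and with wide uncertainty. The estimated value for compound 3 is 6000 nM in this assay with 2000 nM to 15000 nM as the expected range.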

Compound 3, half-maximal inhibitory concentration: 2080 nM
Compound 3: middle estimate off by 2.9-fold (0.46 log units), on the high side, within the range that was stated.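

In this assay, 3-hydroxyazetidin-1-yl in place of 4-methylpiperidin-1-yl on a carbonyl carbon gives a 1.1-fold lower number from compound 2 to compound 3 (0.02 log units; within the scatter), so this assay does not tell the two groups apart, although they differ in ring size, heavy-atom count and hydrogen-bond donors. The methyl of compound 2 is therefore not needed for this level of activity, and a second group, 3-hydroxyazetidin-1-yl, also separates from piperidin-1-yl, with an at least 4.8-fold lower number from compound 1 to compound 3 (0.68 log units; beyond the scatter). That step is bounded on one side only, because compound 1 carries a limit and not a number: the limit of > 10000 nM in this assay, at which 1 of the 3 values shown sits.

On these data alone, whether the hydroxyl or the four-membered ring accounts for the level of compound 3 stays open, as does how an azetidin-1-yl group without the hydroxyl, a 4-hydroxypiperidin-1-yl group or an open-chain dimethylamino group would read in this assay. With only three groups shown at this carbonyl, it also remains open whether any other group here could move the number well away from those of compound 2 and compound 3.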